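Benzyl substitution and Jurkat functional potency in the oxalamide series

The source may hold more compounds than are shown below. What is called first, only, known or untested is meant among the compounds shown, and "the series" means these compounds.

Measured compounds:
compound 1, `C[C@H](NC(=O)C(=O)NCc1ccc(Cl)cc1)C(=O)N[C@@H](CC(=O)O)C(=O)COc1c(F)c(F)cc(F)c1F`, 8.4 nM
compound 2, `C[C@H](NC(=O)C(=O)NCc1ccccc1F)C(=O)N[C@@H](CC(=O)O)C(=O)COc1c(F)c(F)cc(F)c1F`, 207 nM
compound 3, `C[C@H](NC(=O)C(=O)NCc1ccc(F)cc1)C(=O)N[C@@H](CC(=O)O)C(=O)COc1c(F)c(F)cc(F)c1F`, 197 nM

In a functional assay on Jurkat cells (Homo sapiens) (a higher number here means a weaker inhibitor, a lower number a stronger inhibitor), compound 1 gives the lowest of the three numbers; compound 3 is the nearest and compound 2 the furthest. Both steps away from it were large: a 25-fold higher number from compound 1 to compound 2 (1.39 log units; beyond the scatter) and a 23-fold higher number from compound 1 to compound 3 (1.37 log units; beyond the scatter). Compounds 2 and 3 lie within the scatter of each other: a 1.1-fold lower number from compound 2 to compound 3 (0.02 log units; within the scatter).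

Compound 4 is `C[C@H](NC(=O)C(=O)NCc1cc(F)cc(F)c1)C(=O)N[C@@H](CC(=O)O)C(=O)COc1c(F)c(F)cc(F)c1F`. Change from compound 1: 3,5-difluorophenyl in place of 4-chlorophenyl on a saturated chain carbon bound to an amide-type nitrogen. The two measured steps from compound 1 bear on this one, since both replace 4-chlorophenyl and both moved the number in this assay upward well beyond the scatter. Going by the values given here, the expected result is a step in the same direction, an 18-fold higher number from compound 1 to compound 4 (1.25 log units; beyond the scatter), with no measured step available to narrow its size. Compound 4 is estimated at 150 nM, range 40 nM to 600 nM.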

Compound 4, half-maximal inhibitory concentration: 16 nM
Estimate against measurement, compound 4: 9.4-fold (0.97 log units) above; measured number below the stated range.
By their numbers in this assay, from the lowest: compounds 1 and 4 (each within the scatter of the next); then compounds 3 and 2 (each within the scatter of the next).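

Replacing the 4-chlorophenyl need not lose activity at this position: in this assay the 3,5-difluorophenyl stays within the scatter of it (a 1.9-fold higher number from compound 1 to compound 4 (0.28 log units; within the scatter)). Among the fluorinated groups, the number and placing of the fluorines on the ring matter, since the 3,5-difluorophenyl clearly separates from both the 4-fluorophenyl (a 12-fold lower number from compound 3 to compound 4 (1.09 log units; beyond the scatter)) and the 2-fluorophenyl (a 13-fold lower number from compound 2 to compound 4 (1.11 log units; beyond the scatter)). Nothing measured here offers a reason for this.

Still open, as far as these compounds go, is whether a bromo, methoxy or trifluoromethyl group on the ring keeps the number of compound 1. Also open, from the compounds shown here alone, is how a longer chain between the ring and the amide-type nitrogen would read in this assay.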